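The source may hold more compounds than are shown below. What is called first, only, known or untested is meant among the compounds shown, and "the series" means these compounds.

Measured so far in a functional assay for agonist activity at Bile acid receptor (Homo sapiens), read by FRET; a lower number here means that less compound is needed, a higher number that more compound is needed for the effect:
compound 1, `CC(C)c1onc(-c2c(Cl)cccc2Cl)c1COc1ccc(-c2ccc3c(C(=O)O)nccc3c2)cc1` — 380 nM
compound 2, `Cc1cc(OCc2c(-c3c(Cl)cccc3Cl)noc2C(C)C)ccc1-c1ccc2nc(C(=O)O)ccc2c1` — 250 nM
compound 3, `CC(C)c1onc(-c2c(Cl)cccc2Cl)c1COc1ccc(-c2ccc3nc(C(=O)O)cc(O)c3c2)cc1` — 51 nM

Compound 3 stands lowest of the three in this assay; compound 2 and compound 1 both sit beyond the scatter above it. Compound 4, `CCOc1cc(C(=O)O)nc2ccc(-c3ccc(OCc4c(-c5c(Cl)cccc5Cl)noc4C(C)C)cc3)cc12`, has not yet been measured. It differs from compound 3 in one place only: ethyl in place of hydrogen on an oxygen on an aromatic ring. For the measured compounds named here, no measured pair shows this change, so the size of the step is unknown. The expectation is that the change leaves the number of compound 3 roughly where it is or raises it a little, a 2.0-fold higher number from compound 3 to compound 4 (0.29 log units; within the scatter), close to the scatter. Compound 4 is therefore expected to give about 100 nM in this assay, somewhere between 30 nM and 350 nM.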

Compound 4, half-maximal effective concentration: 52 nM
Compound 4: middle estimate off by 1.9-fold (0.28 log units), on the high side; low and high end bracket the measured number.
By their numbers in this assay, from the lowest: compounds 3 and 4 (each within the scatter of the next); then compounds 2 and 1 (each within the scatter of the next).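

In this assay, replacing hydroxy with ethoxy gives a 1.0-fold higher number from compound 3 to compound 4 (0.01 log units; within the scatter), so the two compounds cannot be told apart. For the compounds shown here, this is the first direct test of this position, and it shows that the oxygen on the aromatic ring can carry an ethyl group in place of its hydrogen with the number staying within the scatter. Nothing measured here explains why the two compounds match. Still open, going by these compounds, is how far this tolerance extends: whether a longer chain such as butyl on the oxygen, or a bulkier ring such as benzyl, would keep the number there. Also open, on these data alone, is whether an amine in place of the oxygen would do the same.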